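The source may hold more compounds than are shown below. What is called first, only, known or untested is meant among the compounds shown, and "the series" means these compounds.

Working notes on the series.

Three aryl ureas sharing one core have been measured in a functional assay on HepG2 cells (Homo sapiens) for inhibition, read by MTT assay, with a stated time of 72 h; on this read-out higher numbers stand for weaker inhibition and lower numbers for stronger inhibition. Compound 1 `COc1cccc(-n2cc(COc3cccc(NC(=O)Nc4ccc(Cl)c(C(F)(F)F)c4)c3)nn2)c1` gives 1310 nM. Compound 2 `CC(C)c1cccc(-n2cc(COc3cccc(NC(=O)Nc4ccc(Cl)c(C(F)(F)F)c4)c3)nn2)c1` gives 3250 nM. Compound 3 `O=C(Nc1cccc(OCc2cn(-c3ccc(I)cc3)nn2)c1)Nc1ccc(Cl)c(C(F)(F)F)c1` gives 2690 nM. On these numbers compound 3 stands second highest of the three: its nearest neighbour is compound 2, a gap within the scatter, and its furthest is compound 1, which lies below it beyond the scatter, as the step of a 2.1-fold higher number from compound 1 to compound 3 (0.31 log units; beyond the scatter) records.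

Compound 4 `COc1ccccc1-n1cc(COc2cccc(NC(=O)Nc3ccc(Cl)c(C(F)(F)F)c3)c2)nn1` is not yet measured. It differs from compound 3 by 2-methoxyphenyl in place of 4-iodophenyl on an aromatic nitrogen. Within the data shown here, two measured steps bear on this position. The step of a 1.2-fold lower number from compound 2 to compound 3 (0.08 log units; within the scatter) shows that swapping one aryl group on this nitrogen for another need not move the read-out at all. The step of a 2.1-fold higher number from compound 1 to compound 3 (0.31 log units; beyond the scatter) shows that a methoxyphenyl in this place sat lower than the 4-iodophenyl, although that methoxy stood at a different ring position from the one entering here. Taken together, a modest move toward a lower number is expected for compound 4, but with wide uncertainty because the 2-methoxy pattern itself has no precedent among the measured compounds.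

Compound 4 is therefore estimated at 1800 nM in this assay, within the range 900 nM to 3600 nM, corresponding to an expected step of a 1.5-fold lower number from compound 3 to compound 4 (0.17 log units; within the scatter).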

Compound 4, half-maximal inhibitory concentration: 11300 nM
Estimate against measurement, compound 4: 6.3-fold (0.80 log units) below; the measured number lies above the stated range.
By their numbers in this assay, from the lowest: compound 1; then compounds 3 and 2 (each within the scatter of the next); then compound 4.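

The aryl group on this aromatic nitrogen can move the read-out in this assay much further than the earlier swaps suggested, as the step of a 4.2-fold higher number from compound 3 to compound 4 (0.62 log units; beyond the scatter) and the step of a 3.5-fold higher number from compound 2 to compound 4 (0.54 log units; beyond the scatter) both show, leaving compound 4 the weakest of the four. Among these compounds, the step of an 8.6-fold higher number from compound 1 to compound 4 (0.94 log units; beyond the scatter) is the sharpest finding, since the group entering and the group leaving differ only in where the methoxy stands on the phenyl ring, so a methoxyphenyl on this nitrogen does not by itself fix the read-out, and the earlier compounds held no such pair. Nothing at hand gives a measured reason for this shift.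

The compounds shown leave open whether the higher number goes with the methoxy group specifically or would also follow another group in the same ring position, such as a chlorine or a methyl. Also open, from the compounds shown here alone, is how an amine or a carboxylic acid on this phenyl ring would sit against the methoxyphenyl pair, and whether the same order would hold in a read-out other than this assay.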